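A few compounds are considered here, and "the series" means these few. Any claim that something is new, unique, unknown or untested is made for them only; others in the source may bear on it.

In a functional assay on HCT-15 cells (Homo sapiens) for antiproliferative activity, read by MTT assay, with a stated time of 72 h (on this read-out higher numbers stand for weaker inhibition and lower numbers for stronger inhibition), three compounds have been measured. Compound 1 `COc1cc(-c2nccn2S(=O)(=O)c2ccc(C)cc2)cc(OC)c1OC` gives > 100000 nM, which is a limit of the assay and not a number. Compound 3 `COc1cc(-c2nccn2-c2ccc3sccc3c2)cc(OC)c1OC` gives 3300 nM. Compound 2 `COc1ccc(-n2ccnc2-c2cc(OC)c(OC)c(OC)c2)cc1[N+](=O)[O-]` gives 1000 nM, the lower of the two actual numbers, and its gap to compound 3 lies beyond the usual scatter. Compound 4 `COc1cc(-c2nccn2-c2cccc([N+](=O)[O-])c2)cc(OC)c1OC` differs from compound 2 in one place: hydrogen in place of methoxy on an aromatic carbon, with hydrogen in place of methoxy on an aromatic carbon, ortho to a nitro group. Among the compounds with values here, no measured pair shows this change, so a modest weakening in this assay, somewhat beyond the scatter, is only an expectation. The expected change is a 2.5-fold higher number from compound 2 to compound 4 (0.40 log units; beyond the scatter). Compound 4 is estimated at 2500 nM, within an expected range of 700 nM to 9000 nM.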

Compound 4, half-maximal inhibitory concentration: > 100000 nM
Compound 4 gave a limit, no number; the forecaster's own chance of this, stated with the estimate: 6%; middle value at least 40-fold (1.60 log units) away from the limit.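

In this assay, hydrogen in place of methoxy on the aromatic carbon ortho to a nitro group gives an at least 100-fold higher number from compound 2 to compound 4 (2.00 log units; beyond the scatter). Within the data shown here, this is the first pair to isolate this position, and it shows that the single change takes compound 2 from a measured number to no number at all. The value of compound 4 is a limit and not a number, so the step's full size stays unknown: the limit of > 100000 nM in this assay, at which 2 of the 4 values shown sit.

As far as these compounds go, whether the methoxy itself is needed at this position stays open. An ethoxy, a hydroxyl or an amine there could separate the methoxy from other groups.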